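Swapping the Hydroxamic Acid Tail for an Aminoanilide

This account rests on a few compounds, and the source may have more. Where it says the series, first, only, none or still open, it means among the compounds named here.

Compound 3 `Cn1cc(-c2ccccc2Oc2ccccc2)c2cc(C(=O)NCCCCCC(=O)NO)[nH]c2c1=O` gives 3.4 nM in an assay on isolated protein for inhibition of protein deacetylase HDAC6 (Homo sapiens), read by fluorescence (a lower number here means a stronger inhibitor, a higher number a weaker inhibitor), the lowest of the three numbers measured, though compound 1 `Cn1cc(-c2ccccc2Oc2ccccc2)c2cc(C(=O)NCCCCCCC(=O)NO)[nH]c2c1=O`, which gives 4.7 nM, sits close by; compound 2 `Cn1cc(-c2ccccc2Oc2ccccc2)c2cc(C(=O)NCCCC(=O)NO)[nH]c2c1=O` gives 144 nM. Compound 4 `Cn1cc(-c2ccccc2Oc2ccccc2)c2cc(C(=O)NCCCCC(=O)Nc3ccccc3N)[nH]c2c1=O` is not yet measured; it differs from compound 3 by (2-aminophenyl)carbamoyl in place of (hydroxycarbamoyl)methyl on a saturated chain carbon, four bonds along the chain from an amide-type nitrogen. Going by the values given here, none of the measured steps makes this swap: a 1.4-fold lower number from compound 1 to compound 3 (0.14 log units; within the scatter) and a 31-fold higher number from compound 1 to compound 2 (1.49 log units; beyond the scatter) only shorten the chain, and a 42-fold lower number from compound 2 to compound 3 (1.63 log units; beyond the scatter) lengthens it, while every measured compound keeps a hydroxycarbamoyl group. With that group gone, a much weaker result is expected for compound 4, a step of an 880-fold higher number from compound 3 to compound 4 (2.95 log units; beyond the scatter) in this assay. Compound 4 is therefore estimated at 3000 nM, within a range of 400 nM to 20000 nM.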

Compound 4, half-maximal inhibitory concentration: > 500 nM
Compound 4 was reported as a limit (the forecaster's own chance of this, stated with the estimate: 25%); the middle value is on the limit's open side.
By their numbers in this assay, from the lowest: compounds 3 and 1 (each within the scatter of the next); then compound 2. At a limit, above all of these: compound 4.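

In this assay compound 4 gives > 500 nM, which is a limit of the assay and not a number. Until now only chain length had changed, but replacing the hydroxycarbamoyl end with the larger (2-aminophenyl)carbamoyl end gives an at least 140-fold higher number from compound 3 to compound 4 (2.16 log units; beyond the scatter) and an at least 100-fold higher number from compound 1 to compound 4 (2.02 log units; beyond the scatter), both large. Even the short-chain hydroxycarbamoyl compound keeps a lead, with an at least 3.4-fold higher number from compound 2 to compound 4 (0.54 log units; beyond the scatter).

As far as these compounds go, the true value of compound 4 remains unknown. Also open, from the compounds shown here alone, is whether a (2-aminophenyl)carbamoyl group on a longer chain, or a carboxylic acid at this chain end, would bring the number down.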